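The source may hold more compounds than are shown below. What is called first, only, known or untested is meant among the compounds shown, and "the series" means these compounds.

In an ADME assay on RD cells (Homo sapiens) for cytotoxicity (a higher number here means that more compound is tolerated, a lower number that less compound is tolerated), compound 2 `CN(C)C(=S)N/N=C1/C(=O)Nc2ccccc21` gives > 25000 nM, which is a limit of the assay rather than a number. Compound 1 `O=C1/C(=N\NC(=S)Nc2ccccc2)c2ccccc2N1c1ccccc1` likewise gives > 25000 nM in this assay, again a limit. Both values sit at one point, (the limit of > 25000 nM in this assay, at which 2 of the 2 values shown sit). Compound 3 `CCCN(CCC)C(=S)N/N=C1/C(=O)Nc2ccccc21` has not yet been measured; it differs from compound 2 by dipropylamino in place of dimethylamino on a thiocarbonyl carbon. Within the data shown here, no step between measured compounds is known, so no shift beyond the scatter is expected in this assay, and the expected step is a number no higher from compound 2 to compound 3 (the limit leaves the size open). Compound 3 is therefore estimated at 25000 nM, between 10000 nM and 60000 nM, most likely reported again as a limit.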

Compound 3, half-maximal cytotoxic concentration: > 25000 nM
Compound 3 ended at the assay's limit (the forecaster's own chance of this, stated with the estimate: 70%); the middle value lies on the limit itself.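

Among these compounds, compound 3, like compound 2, stands at a limit of this assay, so no step between the two can be read. The compounds shown leave open whether dipropylamino in place of dimethylamino changes the tolerated concentration at all, and where any of the three would reach its half-maximal cytotoxic concentration.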